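Compound 2 to compound 3: swapping the hydroxyl-bearing side group

The source may report more compounds than this note shows. Statements on the series, on what has been measured and on what is new or still open speak of the compounds shown alone.

In a functional assay on SW480 cells (Homo sapiens) for antiproliferative activity, read by MTT assay, with a stated time of 48 h (on this read-out higher numbers stand for weaker inhibition and lower numbers for stronger inhibition), compound 1 (`C=C(CO)C(CCCCC)n1cnc2c(Cl)ncnc21`) gives > 50000 nM. That reading is a limit, not a number. For the measured compounds named here, compound 2 (`CCCCCCCC(CCO)n1cnc2c(Cl)ncnc21`) gives 3630 nM, the only true number so far, so it stands as the sole numeric reference point for the series. Compound 3 (`C=C(CO)C(CCCCCCC)n1cnc2c(Cl)ncnc21`) has not yet been measured in this assay. It carries 1-(hydroxymethyl)ethenyl in place of 2-hydroxyethyl on a saturated chain carbon bound to an aromatic nitrogen and a saturated chain carbon. Going by the values given here, no measured step informs this change, so the expectation starts from compound 2 at 3630 nM. The limit seen for compound 1 keeps the weak side of the range open. The expected step is a 1.4-fold higher number from compound 2 to compound 3 (0.14 log units; within the scatter), leaning slightly towards weaker inhibition without clearly leaving the usual scatter. The estimate for compound 3 is 5000 nM, with an expected range of 1200 nM to 20000 nM.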

Compound 3, half-maximal inhibitory concentration: 29400 nM
Estimate against measurement, compound 3: 5.9-fold (0.77 log units) below, outside the stated range (above it).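

In this assay, for the compounds shown here, 1-(hydroxymethyl)ethenyl in place of 2-hydroxyethyl on a saturated chain carbon bound to an aromatic nitrogen and a saturated chain carbon weakens inhibition: an 8.1-fold higher number from compound 2 to compound 3 (0.91 log units; beyond the scatter), the first readable evidence that this position responds to this change. The second step, an at least 1.7-fold lower number from compound 1 to compound 3 (0.23 log units; that floor lies within the scatter), places ethyl in place of hydrogen on a saturated chain carbon, six bonds along the chain from an aromatic nitrogen and a double-bonded chain carbon, and its floor sets no order between the two compounds. Compound 1 gives a limit, not a number: the limit of > 50000 nM in this assay, at which 1 of the 3 values shown sits.

The compounds shown do not separate the double bond from the added carbon of 1-(hydroxymethyl)ethenyl. Also open, going by these compounds, is how an amine or a carboxylic acid in place of the hydroxyl would read, and how a longer chain would read with either side group.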